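The source may report more compounds than this note shows. Statements on the series, on what has been measured and on what is new or still open speak of the compounds shown alone.

In an ADME assay on Vero 76 cells (Chlorocebus sabaeus) for cytotoxicity, read by MTT assay, with a stated time of 96 h (a higher number here means that more compound is tolerated, a lower number that less compound is tolerated), the measured compounds sit close together. Compound 1 `NS(=O)(=O)c1ccc(N2N=C(c3ccc(OCc4ccccc4)cc3)CC2c2ccc(F)cc2)cc1` gives 90000 nM, compound 2 `Cc1ccc(C2CC(c3ccc(OCc4ccccc4)cc3)=NN2c2ccc(S(N)(=O)=O)cc2)cc1` gives 100000 nM and compound 3 `Cc1ccc(C2CC(c3ccc(Oc4ccccc4)cc3)=NN2c2ccc(S(N)(=O)=O)cc2)cc1` gives 86000 nM, so compound 2 stands within the scatter of the other two. Compound 4 `NS(=O)(=O)c1ccc(N2N=C(c3ccc(OCc4ccccc4)cc3)CC2c2cccc(F)c2)cc1` follows from compound 2 with 3-fluorophenyl in place of 4-methylphenyl on a saturated ring carbon. The nearest measured change is methyl in place of fluoro on an aromatic carbon, a 1.1-fold higher number from compound 1 to compound 2 (0.05 log units; within the scatter). Phenyl in place of benzyl on an oxygen gave a 1.2-fold lower number from compound 2 to compound 3 (0.07 log units; within the scatter). Both steps lie within the scatter, so no step beyond it is expected in this assay. For the measured compounds named here, no measured compound carries 3-fluorophenyl. The estimated change is a 1.1-fold lower number from compound 2 to compound 4 (0.05 log units; within the scatter). Compound 4 is expected at 90000 nM, with an estimated range of 55000 nM to 130000 nM.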

Compound 4, half-maximal cytotoxic concentration: 90000 nM
Compound 4: the middle estimate sits on the measured number at the digits printed; the measured number falls inside the stated range.
By their numbers in this assay, from the lowest: compounds 3, 1, 4 and 2 (each within the scatter of the next).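

On the saturated ring carbon in this assay, 3-fluorophenyl in place of 4-methylphenyl gives a 1.1-fold lower number from compound 2 to compound 4 (0.05 log units; within the scatter), and 3-fluorophenyl in place of 4-fluorophenyl gives no change at the digits printed from compound 1 to compound 4 (within the scatter). The fluorine's ring position on this phenyl thus joins the methyl-for-fluoro change as a step within the scatter, and all four compounds remain within the scatter of the next. No data on hand bear on a cause for this flat result. Open, as far as these compounds go, is whether a phenyl carrying an amine or a carboxylic acid, or a pyridine ring, on this carbon would stay within the scatter. Also open, from the compounds shown here alone, is whether replacing the 4-sulfamoylphenyl group with another group would shift the number.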